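A few compounds are considered here, and "the series" means these few. Any claim that something is new, unique, unknown or untested is made for them only; others in the source may bear on it.

Measured so far:
compound 1, `CCCCCCCCCCCCCCNC(=O)[C@H](CO)/N=C/c1ccccc1[N+](=O)[O-]`, 21700 nM
compound 2, `CCCCCCCCCCCCCCNC(=O)[C@H](CO)/N=C/c1ccccc1OC`, 12500 nM
compound 3, `CCCCCCCCCCCCCCNC(=O)[C@H](CO)NCc1ccccc1OC`, 100000 nM

Compound 4, `CCCCCCCCCCCCCCNC(=O)[C@H](CO)NCc1ccccc1[N+](=O)[O-]`, has not yet been tested in a functional assay on cells (Homo sapiens) for cytotoxicity, read by MTT assay, with a stated time of 24 h; a higher number here means a weaker inhibitor, a lower number a stronger inhibitor. Compound 2 and compound 1 share one core, compound 3 and compound 4 another; the two cores differ by a group of 10 heavy atoms (8 carbon, 1 nitrogen, 1 oxygen; one six-membered aromatic ring of carbon only) in place of a group of 10 heavy atoms (8 carbon, 1 nitrogen, 1 oxygen; one six-membered aromatic ring of carbon only), on a saturated chain carbon bound to a carbonyl carbon and a saturated chain carbon, a change that gave an 8.0-fold higher number from compound 2 to compound 3 (0.90 log units; beyond the scatter). Within the first core, the exchange nitro in place of methoxy on an aromatic carbon gave a 1.7-fold higher number from compound 2 to compound 1 (0.24 log units; within the scatter). The exchange planned for compound 4, (nitro in place of methoxy on an aromatic carbon), is the same change, made at the same kind of place. Going by the values given here, the one earlier example, which stayed within the scatter, is the only guide, and it rests on a single pair. Compound 4 is therefore expected to land near compound 3, with a 1.2-fold higher number from compound 3 to compound 4 (0.08 log units; within the scatter), and the estimate for compound 4 is 120000 nM, between 50000 nM and 300000 nM.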

Compound 4, half-maximal inhibitory concentration: 29400 nM
Beside the measured number, compound 4's estimate is 4.1-fold (0.61 log units) above it; the whole stated range lies above it.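

In this assay, nitro in place of methoxy on an aromatic carbon gave a 3.4-fold lower number from compound 3 to compound 4 (0.53 log units; beyond the scatter). The same exchange did not carry over unchanged from one core to the other: the same change on two cores in this assay, a 1.7-fold higher number (0.24 log units; within the scatter) from compound 2 to compound 1 and a 3.4-fold lower number (0.53 log units; beyond the scatter) from compound 3 to compound 4, 5.9-fold (0.77 log units) apart, beyond the scatter of two such steps

Going by these compounds alone, this shows that, in these four compounds, the outcome of the exchange depends on the core it is made on, but with only one pair per core it does not show why, or how any other core would respond. The compounds shown leave open what an amine or a carboxylic acid on the same aromatic carbon would do on either core. They also leave open whether a shorter chain in place of the long one would alter this difference between the cores.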